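This account rests on a few compounds, and the source may have more. Where it says the series, first, only, none or still open, it means among the compounds named here.

Compound 1, `C=C(Br)C(=O)Nc1ccc(/C=C2\SC(=O)N(Cc3ccccc3)C2=O)cc1`: 3000 nM
Compound 2, `C=C(Br)C(=O)Nc1ccc(/C=C2\SC(=O)N(Cc3ccc(C(F)(F)F)cc3)C2=O)cc1`: 23000 nM
Compound 3, `C=C(Br)C(=O)Nc1ccc(/C=C2\SC(=O)N(Cc3cccc(F)c3)C2=O)cc1`: 4000 nM

All three were tested in a functional assay on FM3A cells (Mus musculus) for cytotoxicity, read by cell counting, with a stated time of 2 days; a higher number here means a weaker inhibitor, a lower number a stronger inhibitor. Compound 1 gives the lowest number of the three, with one step to a neighbour within the scatter (a 1.3-fold higher number from compound 1 to compound 3 (0.12 log units; within the scatter)) and one beyond it (a 7.7-fold higher number from compound 1 to compound 2 (0.88 log units; beyond the scatter)). Compound 4, `Nc1ccc(/C=C2\SC(=O)N(Cc3ccccc3)C2=O)cc1`, differs from compound 1 in a single place: hydrogen in place of (1-bromoethenyl)carbonyl on a nitrogen on an aromatic ring. For the measured compounds named here, every measured step alters only the group on the saturated chain carbon bound to the ring nitrogen, while the (1-bromoethenyl)carbonyl group is kept in compounds 1, 2 and 3; no measured step therefore bears on this change, and the expectation rests on the change alone. Removing a group shared by every measured compound is expected to give a step toward a higher number, larger than any step seen so far: a 10-fold higher number from compound 1 to compound 4 (1.00 log units; beyond the scatter). Compound 4 is estimated at 30000 nM, within 5000 nM to 100000 nM.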

Compound 4, half-maximal inhibitory concentration: 24000 nM
The estimate for compound 4 lay 1.3-fold (0.10 log units) above the measured number; the measured number falls inside the stated range.
By their numbers in this assay, from the lowest: compounds 1 and 3 (each within the scatter of the next); then compounds 2 and 4 (each within the scatter of the next).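

In this assay, replacing the (1-bromoethenyl)carbonyl group on the nitrogen with hydrogen gives an 8.0-fold higher number from compound 1 to compound 4 (0.90 log units; beyond the scatter) and is the first change shown at this position. The earlier compounds shown here varied only the other end of the molecule, so this step shows that this nitrogen's substituent also affects the number, while the bare amino compound still gives a measurable value. No measurement shown explains this step.

Which part of the lost group matters remains open. A propanoyl or acryloyl group on the same nitrogen would test whether the bromine or the double bond contributes.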